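Enlarging a Saturated Ring at the Edge of Compound 3

The source may report more compounds than this note shows. Statements on the series, on what has been measured and on what is new or still open speak of the compounds shown alone.

Three measured compounds share one core and differ only in the aromatic group attached to a saturated chain carbon bound to a nitrogen on an aromatic ring and a saturated chain carbon. Compound 1 `CC[C@@H](Nc1c(Nc2cccc(C(=O)N(C)C)c2O)c(=O)c1=O)c1ccc(C)s1` gives in an assay on CHO cells for displacement of a labelled ligand from C-X-C chemokine receptor type 1 (Homo sapiens) (on this read-out lower numbers stand for stronger inhibition and higher numbers for weaker inhibition), a value of 146 nM. Compound 2 `CC[C@@H](Nc1c(Nc2cccc(C(=O)N(C)C)c2O)c(=O)c1=O)c1sccc1C` gives in this assay a value of 123 nM; the step of a 1.2-fold lower number from compound 1 to compound 2 (0.07 log units; within the scatter) lies within the scatter, so these two numbers cannot be ordered. Compound 3 `CC[C@@H](Nc1c(Nc2cccc(C(=O)N(C)C)c2O)c(=O)c1=O)c1cc(C2CCCC2)co1` gives in this assay a value of 53 nM, the lowest of the three, since both a 2.8-fold lower number from compound 1 to compound 3 (0.44 log units; beyond the scatter) and a 2.3-fold lower number from compound 2 to compound 3 (0.37 log units; beyond the scatter) are beyond the scatter.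

Compound 4 `CC[C@@H](Nc1c(Nc2cccc(C(=O)N(C)C)c2O)c(=O)c1=O)c1cc(C2CCCCC2)co1` differs from compound 3 in one place: cyclohexyl in place of cyclopentyl on an aromatic carbon. Within the data shown here, no measured step bears directly on this change. Each earlier step replaced the entire aromatic group, whereas here the aromatic ring is kept and only the saturated ring on an aromatic carbon of a five-membered aromatic ring with 1 oxygen grows by one carbon. Among the measured compounds shown here, with no step that isolates this ring size, the expected outcome is no movement beyond the scatter, that is a 1.1-fold lower number from compound 3 to compound 4 (0.03 log units; within the scatter). Compound 4 is therefore estimated at 50 nM, with a range from 22 nM to 115 nM.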

Compound 4, inhibition constant: 283 nM
The estimate for compound 4 lay 5.7-fold (0.75 log units) below the measured number, outside the stated range (above it).
By their numbers in this assay, from the lowest: compound 3; then compounds 2, 1 and 4 (each within the scatter of the next, the first and the last beyond it).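

In this assay, among these compounds, a single extra ring carbon on an aromatic carbon of a five-membered aromatic ring with 1 oxygen is enough to shift the number beyond the scatter (a 5.3-fold higher number from compound 3 to compound 4 (0.73 log units; beyond the scatter)), whereas the earlier steps had only compared whole aromatic groups. The advantage of compound 3 over the methylthiophene compounds therefore does not come from the oxygen-containing aromatic ring alone: with cyclohexyl on that same ring, the comparison with 3-methylthiophen-2-yl reverses (a 2.3-fold higher number from compound 2 to compound 4 (0.36 log units; beyond the scatter)), and the comparison with 5-methylthiophen-2-yl gives no readable order (a 1.9-fold higher number from compound 1 to compound 4 (0.29 log units; within the scatter)). No supporting data are available to explain why this small growth of the saturated ring has so large an effect.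

The compounds shown leave open how the number responds to smaller saturated rings at this carbon, such as cyclobutyl or cyclopropyl, or to an open chain such as isopropyl. They also leave open what happens when the cyclohexyl ring is replaced by a six-membered ring containing another atom, such as tetrahydropyranyl or piperidinyl.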